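The source may report more compounds than this note shows. Statements on the series, on what has been measured and on what is new or still open speak of the compounds shown alone.

In an ADME assay on MT4 cells (Homo sapiens) for cytotoxicity, read by MTT assay, with a stated time of 5 days (on this read-out higher numbers stand for lower toxicity in this test and lower numbers for higher toxicity in this test), three compounds sharing one core have been read. Compound 1 (`CNc1cc(Oc2c(OC)cc3cc(C#N)ccc3c2OC)nc(Nc2ccc(C#N)cc2)n1`) gives 239000 nM as a true number. Compound 2 (`COc1cc2cc(C#N)ccc2c(OC)c1Oc1cc(NCC(C)(C)C)nc(Nc2ccc(C#N)cc2)n1`) gives > 125000 nM and this is a limit. Compound 3 (`COc1cc2cc(C#N)ccc2c(OC)c1Oc1cc(NC2CC2)nc(Nc2ccc(C#N)cc2)n1`) gives > 125000 nM and this too is a limit, so it has no exact position on the scale. The series thus shows (the limit of > 125000 nM in this assay, at which 2 of the 3 values shown sit).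

Compound 4 (`COc1cc2cc(C#N)ccc2c(OC)c1Oc1cc(NC2CCOCC2)nc(Nc2ccc(C#N)cc2)n1`) carries oxan-4-yl in place of cyclopropyl on a nitrogen on an aromatic ring. The measured changes at that nitrogen are (a step that the limit leaves unreadable from compound 1 to compound 2), (a step that the limit leaves unreadable from compound 1 to compound 3) and (a step that the two limits leave unreadable from compound 2 to compound 3), and none has a readable size. They offer no direction, so no step beyond the scatter is expected in this assay here. The expected step is small (a step that the limit leaves unreadable from compound 3 to compound 4) and its sign is open. For the measured compounds named here, the only number available is that of compound 1 at 239000 nM and the estimate stays close to it. Compound 4 is expected at 180000 nM (estimated range 80000 nM to 400000 nM).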

Compound 4, half-maximal cytotoxic concentration: > 125000 nM
Compound 4: a limit, no number; the forecaster's own chance of this, stated with the estimate: 75%; the middle value does not contradict the limit.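

No step from compound 1, compound 2 or compound 3 to compound 4 can be read, because the result for compound 4 is again a limit: the limit of > 125000 nM in this assay, at which 3 of the 4 values shown sit.

The compounds shown leave open the exact values of compound 2, compound 3 and compound 4, and so whether the groups on that nitrogen make any difference.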